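From Chloro to Bromo: A Small Expected Step

The compounds below may be only part of what the source reports. "The series", "measured", "known", "first", "only" and "open" are said of these compounds alone.

Of the compounds shown here, three sharing one core have been measured in a functional assay on HepG2 cells (Homo sapiens) for inhibition, read by MTT assay, with a stated time of 72 h; a lower number here means a stronger inhibitor, a higher number a weaker inhibitor. Compound 1 `O=[N+]([O-])c1ccc(-c2nnc(SCCCN3CCN(c4nc5ccccc5o4)CC3)o2)cc1` gives 67200 nM, compound 2 `Cc1ccc(-c2nnc(SCCCN3CCN(c4nc5ccccc5o4)CC3)o2)cc1` gives 154000 nM, and compound 3 `Clc1ccc(-c2nnc(SCCCN3CCN(c4nc5ccccc5o4)CC3)o2)cc1` gives 121000 nM. Compound 3 lies within the usual scatter of both the others, so its place among them is not a firm ranking.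

The next compound is compound 4 `Brc1ccc(-c2nnc(SCCCN3CCN(c4nc5ccccc5o4)CC3)o2)cc1`, which has bromo in place of chloro on an aromatic carbon, para to a large group: bromo in place of chloro on an aromatic carbon. Among the compounds with values here, no measured step goes from chloro to bromo, so the closest evidence comes from the other swaps at this same place. Replacing nitro with methyl gave a 2.3-fold higher number from compound 1 to compound 2 (0.36 log units; beyond the scatter), a modest step and the only one beyond the scatter. Replacing nitro with chloro gave a 1.8-fold higher number from compound 1 to compound 3 (0.26 log units; within the scatter), and replacing methyl with chloro gave a 1.3-fold lower number from compound 2 to compound 3 (0.10 log units; within the scatter), both within the scatter.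

The last of these is the best guide, as neither of its two compounds carries nitro. No step beyond the scatter is expected in this assay, and the estimated step is a 1.1-fold lower number from compound 3 to compound 4 (0.02 log units; within the scatter). The expected value for compound 4 is 115000 nM, with an estimated range from 65000 nM to 200000 nM.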

Compound 4, half-maximal inhibitory concentration: 67500 nM
Compound 4: middle estimate off by 1.7-fold (0.23 log units), on the high side; the measured number falls inside the stated range.
By their numbers in this assay, from the lowest: compounds 1, 4, 3 and 2 (each within the scatter of the next, the first and the last beyond it).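

In this assay, the exchange of 4-chlorophenyl for 4-bromophenyl gives (a 1.8-fold lower number from compound 3 to compound 4 (0.25 log units; within the scatter)), so these two halogens cannot be told apart at this position, even though the step is not far short of the scatter limit. Bromo does separate from methyl, with (a 2.3-fold lower number from compound 2 to compound 4 (0.36 log units; beyond the scatter)), a modest step that chloro did not achieve against methyl, while against nitro there is effectively no difference at all (a 1.0-fold higher number from compound 1 to compound 4 (0.00 log units; within the scatter)); bromo and nitro are thus the two groups here that stand clear of methyl, although compound 3 with chloro remains within the scatter of compound 4 and so blurs any sharp division among the groups. Nothing available explains why the numbers fall as they do at this position.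

Still open, as far as these compounds go, is whether a quite different group at this place, such as an amine, a carboxylic acid or a fluoro atom, would move the number outside the narrow span seen with these four compounds. Also open, from the compounds shown here alone, is whether a change elsewhere on the shared core, such as a longer chain, would produce a larger step than any of these swaps on the aromatic ring.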